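Trifluoromethyl on the pyridyl ring of a nitrocatechol isoxazole

This account rests on a few compounds, and the source may have more. Where it says the series, first, only, none or still open, it means among the compounds named here.

Compound 1 `O=[N+]([O-])c1cc(-c2cc(-c3cccnc3)no2)cc(O)c1O` gives 33.6% in a functional assay on the whole organism (liver, strain NMRI) for inhibition, with Mus musculus as the target, with a stated time of 3 h, at a dose of 3 mg/kg by the oral route (a higher number here means more inhibition at the dose given (going by the name of the read-out), a lower number less inhibition), and stands second highest of the three measured numbers. Compound 2 `O=[N+]([O-])c1cc(-c2cc(-c3cnccn3)no2)cc(O)c1O` gives 44.7% in this assay, and the change to pyrazin-2-yl in place of pyridin-3-yl brought a number 11.1 percentage points higher from compound 1 to compound 2 (beyond the scatter). Compound 3 `Cc1ccc(-c2cc(-c3cc(O)c(O)c([N+](=O)[O-])c3)on2)c(Cl)n1` gives 21.6% in this assay, the step to 2-chloro-6-methylpyridin-3-yl in place of pyridin-3-yl giving a number 12 percentage points lower from compound 1 to compound 3 (beyond the scatter); between the two substituted heteroaryl variants the step was a number 23.1 percentage points lower from compound 2 to compound 3 (beyond the scatter).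

Compound 4 `O=[N+]([O-])c1cc(-c2cc(-c3cnccc3C(F)(F)F)no2)cc(O)c1O` carries trifluoromethyl in place of hydrogen on an aromatic carbon, ortho to a large group and opposite the ring nitrogen. The step from compound 1 to compound 3 bears most directly on it, since there too groups were added to the same six-membered ring and the number fell by a modest amount. The step from compound 1 to compound 2 alters the ring itself and is less informative. A modest drop beyond the scatter is therefore expected for compound 4, a number 9.6 percentage points lower from compound 1 to compound 4 (within the scatter). For compound 4 the estimate in this assay is 24%, with a range from 10% to 40%.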

Compound 4, a percentage reported as inhibition, in the whole organism at one dose (the size of the read-out at that dose, not a potency): 19.3%
The estimate for compound 4 lay 4.7 percentage points above the measured number, within the range that was stated.
By their numbers in this assay, from the lowest: compounds 4 and 3 (each within the scatter of the next); then compound 1; then compound 2.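

In this assay, trifluoromethyl in place of hydrogen, ortho to a large group and opposite the ring nitrogen, gives a number 14.3 percentage points lower from compound 1 to compound 4 (beyond the scatter), so one added group at this position is enough to lower the number beyond the scatter. Compound 3 carries chloro and methyl together, so its step, a number 12 percentage points lower from compound 1 to compound 3 (beyond the scatter), could not be assigned to either group, whereas the new step isolates one change on the six-membered ring. Nothing available explains the fall in the number for compound 4.

As far as these compounds go, whether the fall belongs to trifluoromethyl itself or would follow any group on this carbon remains open; a methyl, an amine or a carboxylic acid at the same place would test this. From the compounds shown here alone, it is also open how the other positions on the ring respond to trifluoromethyl.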